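The compounds below may be only part of what the source reports. "The series", "measured", "known", "first", "only" and "open" are said of these compounds alone.

Compound 1 `Cc1nc(-c2cccs2)sc1COc1ccc2c(c1)OCC2CC(=O)O`: in a functional assay on CHO cells for agonist activity at Free fatty acid receptor 1 (Homo sapiens), read by FLIPR and calcium flux, tested at 100 nM (a higher number here means a stronger effect of the compound at the concentration tested, a lower number a weaker effect), compound 1 gives 35.2%.
Compound 2 `Cc1nc(-c2ccc(Cl)cc2)sc1COc1ccc2c(c1)OCC2CC(=O)O`: in this assay compound 2 gives 53.4%.

Among these two numbers compound 2 stands highest; its nearest neighbour is compound 1, with a step of a number 18.2 percentage points higher from compound 1 to compound 2 (beyond the scatter).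

Compound 3 `Cc1nc(-c2ccccc2C(F)(F)F)sc1COc1ccc2c(c1)OCC2CC(=O)O` is not yet measured. Its difference from compound 2 is this: 2-(trifluoromethyl)phenyl in place of 4-chlorophenyl on an aromatic carbon.

Among the compounds with values here, only one measured step exists, a number 18.2 percentage points higher from compound 1 to compound 2 (beyond the scatter), and it exchanges thiophen-2-yl for 4-chlorophenyl rather than one substituted phenyl for another, so it bears on the present step only loosely. Within the data shown here, no measured pair shows what trading 4-chlorophenyl for 2-(trifluoromethyl)phenyl does to the number. Compound 3 is therefore expected to stay close to compound 2, with a step of a number 8.4 percentage points lower from compound 2 to compound 3 (within the scatter) that lies within the scatter. The estimate for compound 3 in this assay is 45%, in a range from 20% to 70%.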

Compound 3, a percentage reported as activity, at one concentration (the size of the read-out at that concentration, not a potency): 7.76%
For compound 3 the middle estimate is 37.2 percentage points above the measured one; the whole stated range lies above it.
By their numbers in this assay, from the lowest: compound 3; then compound 1; then compound 2.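

Placing 2-(trifluoromethyl)phenyl instead of 4-chlorophenyl on the aromatic carbon next to the ring nitrogen and next to the ring sulfur gives a number 45.6 percentage points lower from compound 2 to compound 3 (beyond the scatter) in this assay, so carrying a substituted phenyl at this position does not by itself preserve the read-out. The same group also compares poorly with thiophen-2-yl, with a number 27.4 percentage points lower from compound 1 to compound 3 (beyond the scatter), which leaves compound 3 lowest of the three and shows that the gain seen with 4-chlorophenyl does not extend to this substituted phenyl. Nothing available accounts for this fall.

The change alters both the substituent and its place on the phenyl ring at once, and a 2-chlorophenyl or a 4-(trifluoromethyl)phenyl group would be needed to separate the two. As far as these compounds go, how a methoxy group or an amine on that phenyl ring would read also remains open.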